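A Thiophene Swap on the Weakest of Three Anilines

The source may report more compounds than this note shows. Statements on the series, on what has been measured and on what is new or still open speak of the compounds shown alone.

Compound 2 `Cc1cccc(Nc2nccc(-c3ccco3)n2)c1` is the weakest inhibitor among the three measured compounds in a functional assay for inhibition, with Homo sapiens as the target (a higher number here means a weaker inhibitor, a lower number a stronger inhibitor), where compound 2 gives 2100 nM. Compound 1 `c1cc(Nc2nccc(-c3ccco3)n2)cc(-n2ccnc2)c1` gives 800 nM and compound 3 `Cc1cc(C)cc(Nc2nccc(-c3ccco3)n2)c1` gives 700 nM, so both sit below compound 2 by steps beyond the scatter: a 2.6-fold higher number from compound 1 to compound 2 (0.42 log units; beyond the scatter) and a 3.0-fold lower number from compound 2 to compound 3 (0.48 log units; beyond the scatter). Compound 4 `Cc1cccc(Nc2nccc(-c3ccc(C)s3)n2)c1` keeps the aniline side of compound 2 and changes the other ring: 5-methylthiophen-2-yl in place of furan-2-yl on an aromatic carbon. Neither measured step touches this ring, so the two measured steps only show that modest moves are common here and give no direction. For compound 4 a step within the scatter is expected, a 1.3-fold lower number from compound 2 to compound 4 (0.12 log units; within the scatter). Compound 4 is therefore estimated at 1600 nM, with a range from 500 nM to 5000 nM.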

Compound 4, half-maximal inhibitory concentration: 1400 nM
Compound 4: the middle estimate sits 1.1-fold (0.06 log units) above what was measured; low and high end bracket the measured number.
By their numbers in this assay, from the lowest: compounds 3, 1, 4 and 2 (each within the scatter of the next, the first and the last beyond it).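

Within the data shown here, this is the first look at the ring on the far side of the shared core from the aniline, and in this assay placing 5-methylthiophen-2-yl where furan-2-yl stood gives a 1.5-fold lower number from compound 2 to compound 4 (0.18 log units; within the scatter). This position therefore tolerates both a sulfur in place of the oxygen and an added methyl, with no change that stands clear of the scatter. Nothing available here speaks to why.

As far as these compounds go, the two changes arrive together, so the share of each stays open, and plain thiophen-2-yl would separate them. Also open, from the compounds shown here alone, is whether an amine or a carboxylic acid on this ring would move the number beyond the scatter.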